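Methyl on the benzoyl ring in two thiosemicarbazide series

The compounds below may be only part of what the source reports. "The series", "measured", "known", "first", "only" and "open" are said of these compounds alone.

This account concerns three measured compounds and one that is still to be measured, all read in a functional assay on MGC-803 cells (Homo sapiens) for cytotoxicity, read by MTT assay, with a stated time of 72 h; on this read-out lower numbers stand for stronger inhibition and higher numbers for weaker inhibition. Compound 1 `O=C(NC(=S)NNc1ncnc2ccccc12)c1ccccc1` gives 6990 nM. Compound 3 `Cc1ccc(C(=O)NC(=S)NNc2ncnc3ccccc23)cc1` carries the change methyl in place of hydrogen on an aromatic carbon relative to compound 1, and the step of a 1.9-fold lower number from compound 1 to compound 3 (0.27 log units; within the scatter) describes what that did. Compound 2 `COc1cc2ncnc(NNC(=S)NC(=O)c3ccccc3)c2cc1OC` has a different core from compound 1; how the two cores differ is not broken down here. In this assay compound 2 gives 3050 nM, while compound 3 gives 3760 nM, a pair that sit within the scatter of each other.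

Compound 4 `COc1cc2ncnc(NNC(=S)NC(=O)c3ccccc3C)c2cc1OC` differs from compound 2 by methyl in place of hydrogen on an aromatic carbon. Among the measured compounds shown here, this is the same kind of change as the one from compound 1 to compound 3, but not the same: there the methyl entered para to a large group, here it enters ortho to a large group. The earlier step was within the scatter, so on that basis only a small move, if any, is expected from compound 2 to compound 4, and the change of place adds uncertainty rather than a direction. Compound 4 is therefore estimated at 2500 nM in this assay, with a likely range from 1100 nM to 6000 nM. The expected step from compound 2 to compound 4 is a 1.2-fold lower number from compound 2 to compound 4 (0.09 log units; within the scatter), and it rests on the measured step from compound 1 to compound 3.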

Compound 4, half-maximal inhibitory concentration: 11100 nM
For compound 4 the middle estimate is 4.4-fold (0.65 log units) below the measured one; the whole stated range lies below it.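

In this assay the methyl that enters ortho to a large group gives a 3.6-fold higher number from compound 2 to compound 4 (0.56 log units; beyond the scatter), and the two methyl steps in this series do not agree: the same change on two cores in this assay, a 1.9-fold lower number (0.27 log units; within the scatter) from compound 1 to compound 3 and a 3.6-fold higher number (0.56 log units; beyond the scatter) from compound 2 to compound 4, 6.8-fold (0.83 log units) apart, beyond the scatter of two such steps

So within these four compounds, the outcome of adding a methyl to the benzoyl ring on one core gives no reliable guide to the outcome on the other, and the step seen on the core of compound 1 did not carry over to the core of compound 2. What this does not show is which difference matters, since the two steps differ both in the core and in the place of the methyl on the ring, and each rests on a single pair of compounds.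

The compounds shown leave open whether a methyl ortho to a large group would give a similar step on the core of compound 1, and what a methyl at the place it holds in compound 3 would do on the core of compound 2. They also leave open whether an ethyl group, a chlorine or an amine at either place on the benzoyl ring would follow the methyl steps.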